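The compounds below may be only part of what the source reports. "The series", "measured", "known", "first", "only" and "open" are said of these compounds alone.

In an ADME assay on the whole organism with Oryza sativa as the target, tested at 10 uM (a higher number here means a weaker effect of the compound at the concentration tested, a lower number a stronger effect), compound 3 `C[C@H](NC(=O)Nc1ccccc1C(F)(F)F)c1ccccc1` gives 97%, the second highest of three numbers. Its nearest neighbour is compound 1 `Cc1ccccc1NC(=O)N[C@@H](C)c1ccccc1`, which gives 99%; the step of a number 2 percentage points lower from compound 1 to compound 3 (within the scatter) came with trifluoromethyl in place of methyl on an aromatic carbon. Furthest lies compound 2 `C[C@@H](NC(=O)Nc1ccccc1C(F)(F)F)c1ccccc1`, which gives 54%; the step of a number 43 percentage points higher from compound 2 to compound 3 (beyond the scatter) is large, and the fact that compounds 2 and 3 differ only in the configuration as drawn stands with it. Compound 4 `CC(=O)c1ccccc1NC(=O)N[C@@H](C)c1ccccc1` is not yet measured and differs from compound 3 by acetyl in place of trifluoromethyl on an aromatic carbon. Only the earlier step, a change at the same aromatic carbon, bears on this, and it stayed within the scatter. The author therefore expects no step beyond the scatter, a number 2 percentage points lower from compound 3 to compound 4 (within the scatter). Compound 4 is estimated at 95% in this assay, between 80% and 100%.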

Compound 4, a percentage reported as activity, at one concentration (the size of the read-out at that concentration, not a potency): 96%
Beside the measured number, compound 4's estimate is 1 percentage points below it, within the range that was stated.
By their numbers in this assay, from the lowest: compound 2; then compounds 4, 3 and 1 (each within the scatter of the next).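

With acetyl in place of trifluoromethyl the result is a number 1 percentage points lower from compound 3 to compound 4 (within the scatter), and with acetyl in place of methyl it is a number 3 percentage points lower from compound 1 to compound 4 (within the scatter). In this assay, among the compounds shown here, this aromatic carbon has now carried methyl, trifluoromethyl and acetyl, the last bringing a hydrogen-bond acceptor, with no step between them beyond the scatter. Nothing available gives a cause for this result. Going by these compounds, whether an amine or a carboxylic acid at this aromatic carbon would also stay within the scatter remains open. So does whether methyl or acetyl with the opposite configuration as drawn would show a step as large as the one seen with trifluoromethyl.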